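A few compounds are considered here, and "the series" means these few. Any claim that something is new, unique, unknown or untested is made for them only; others in the source may bear on it.

Going by the values given here, compound 2 `O=C(O)CCc1ccc(C#CC2CC2)cc1` gives 5010 nM in a functional assay on 1321-N1 cells for agonist activity at Free fatty acid receptor 1 (Homo sapiens), read by calcium flux, with a stated time of 0.4 s (a higher number here means that more compound is needed for the effect, a lower number that less compound is needed), the higher of the two numbers measured so far. Compound 1 `O=C(O)CCc1ccc(C#CC2CCCC2)cc1` gives 490 nM, and the step of a 10-fold higher number from compound 1 to compound 2 (1.01 log units; beyond the scatter) came with a cyclopropyl in place of a cyclopentyl on a triple-bonded carbon. Compound 3 `C=C(C)C#Cc1ccc(CCC(=O)O)cc1` differs from compound 2 by 1-methylethenyl in place of cyclopropyl on a triple-bonded carbon. Among the compounds with values here, no measured step exchanges a ring for an open chain of the same size, so that single step is only a loose guide. The expected step is a 1.2-fold higher number from compound 2 to compound 3 (0.08 log units; within the scatter), within the scatter. Compound 3 is estimated at 6000 nM, between 2000 nM and 20000 nM.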

Compound 3, half-maximal effective concentration: 417 nM
Beside the measured number, compound 3's estimate is 14-fold (1.16 log units) above it; the measured number lies below the stated range.
By their numbers in this assay, from the lowest: compounds 3 and 1 (each within the scatter of the next); then compound 2.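

At this triple-bonded carbon, the count of heavy atoms alone does not set the result: cyclopropyl and 1-methylethenyl each have 3 carbon atoms, yet the exchange gives a 12-fold lower number from compound 2 to compound 3 (1.08 log units; beyond the scatter) in this position. The open 1-methylethenyl also stands level with the larger ring, with a 1.2-fold lower number from compound 1 to compound 3 (0.07 log units; within the scatter) and no real difference, so among these compounds a ring is not required for the lower number. Going by these compounds, whether a saturated open group such as isopropyl would follow 1-methylethenyl or cyclopropyl remains open. The evidence available does not account for the gap between these two three-carbon groups.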